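The source may report more compounds than this note shows. Statements on the series, on what has been measured and on what is new or still open speak of the compounds shown alone.

Measured compounds in a functional assay on Jurkat cells (Homo sapiens) for activation, with a stated time of 24 h; a higher number here means that more compound is needed for the effect, a lower number that less compound is needed:
compound 1 `Oc1ccccc1CNc1ccc(-c2ccc(F)cc2)cc1`: 3860 nM
compound 2 `CCOc1ccc(-c2ccc(NCc3ccccc3O)cc2)cc1`: 520 nM
compound 3 `Oc1ccccc1CNc1ccc(-c2cccc(F)c2)cc1`: 2020 nM

Compound 3 stands second highest of the three numbers in this assay. Its nearest neighbour is compound 1, where the step of a 1.9-fold lower number from compound 1 to compound 3 (0.28 log units; within the scatter) lies within the usual scatter. Compound 2 gives the lowest number, separated from compound 3 beyond the scatter.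

Compound 4 `CCOc1ccc(-c2ccc(NCc3ccccc3O)cc2)cc1F` is the next compound to be tested. From compound 3 it differs by ethoxy in place of hydrogen on an aromatic carbon; the fluoro group of compound 3 is kept.

Within the data shown here, one measured step bears on this change: a 7.4-fold lower number from compound 1 to compound 2 (0.87 log units; beyond the scatter), where an ethoxy group took the place of a fluoro group on the same ring. In compound 4 the ethoxy group is added rather than exchanged, so the comparison is not exact, but the ethoxy-bearing compound 2 gives the lowest number seen so far. A lowering of the number of about the same size as in that step is expected for compound 4, giving a 5.1-fold lower number from compound 3 to compound 4 (0.70 log units; beyond the scatter) as the estimated step. Compound 4 is therefore estimated at 400 nM in this assay, with a range from 150 nM to 1200 nM.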

Compound 4, half-maximal effective concentration: 2530 nM
Compound 4: the middle estimate sits 6.3-fold (0.80 log units) below what was measured; the measured number lies above the stated range.
By their numbers in this assay, from the lowest: compound 2; then compounds 3, 4 and 1 (each within the scatter of the next).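

In this assay ethoxy in place of hydrogen on the fluoro-bearing ring of compound 3 leaves the number within the scatter (a 1.3-fold higher number from compound 3 to compound 4 (0.10 log units; within the scatter)), so an ethoxy group ortho to a fluoro group and para to a large group does not reproduce the low number of compound 2. With the ethoxy group kept, fluoro in place of hydrogen gives a step beyond the scatter (a 4.9-fold higher number from compound 2 to compound 4 (0.69 log units; beyond the scatter)), so among these compounds the low number goes with ethoxy only where no fluoro group stands ortho to it. No measurement at hand gives a reason for this.

Still open, on these data alone, is whether a chloro or methyl group in the fluoro position would act as the fluoro group does. Also open, as far as these compounds go, is how a propoxy group or an amine would behave in place of ethoxy, with and without the fluoro group.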